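The source may hold more compounds than are shown below. What is called first, only, known or untested is meant among the compounds shown, and "the series" means these compounds.

Among the compounds with values here, in a functional assay on COLO 205 cells (Homo sapiens) for inhibition, read by sulforhodamine B assay, with a stated time of 48 h, tested at 50 uM (on this read-out lower numbers stand for less inhibition of growth and higher numbers for more inhibition of growth at the one concentration tested), compound 1 (`COc1cc(/C=C/C(=O)/C=C/c2cccc3ccccc23)ccc1OCc1cn(CCCOc2cc(=O)oc3ccccc23)nn1`) gives 64%, the highest of the three numbers so far. Compound 2 (`COc1ccc(/C=C/C(=O)/C=C/c2ccc(OCc3cn(CCCCOc4cc(=O)oc5ccccc45)nn3)c(OC)c2)cc1OC`) gives 53%, and compound 3 (`COc1cc(/C=C/C(=O)/C=C/c2ccccc2)ccc1OCc1cn(CCCCOc2cc(=O)oc3ccccc23)nn1`) gives 31%. The next compound to consider, compound 4 (`COc1ccc(/C=C/C(=O)/C=C/c2ccc(OCc3cn(CCCOc4cc(=O)oc5ccccc45)nn3)c(OC)c2)cc1`), keeps the rest of compound 1 and changes one group: 4-methoxyphenyl in place of naphthalen-1-yl, on a double-bonded chain carbon bound to a double-bonded chain carbon (4-methoxyphenyl in place of naphthalen-1-yl on a double-bonded chain carbon bound to a double-bonded chain carbon). Within the data shown here, only one measured step concerns this place: a number 22 percentage points lower from compound 2 to compound 3 (beyond the scatter), a modest drop on exchanging 3,4-dimethoxyphenyl for phenyl. Among the measured compounds shown here, compounds 2 and 3 also differ from compound 1 in a second place, so no measurement yet isolates the loss of naphthalen-1-yl. The entering 4-methoxyphenyl resembles the groups of both compound 2 and compound 3, which suggests a number within or near their range. A modest fall is therefore expected, and the estimated step is a number 16 percentage points lower from compound 1 to compound 4 (beyond the scatter). For compound 4 the expected value is 48%, with an estimated range from 31% to 65%.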

Compound 4, percent growth inhibition at one concentration: 53%
Compound 4: the middle estimate sits 5 percentage points below what was measured, and the stated range covers the measured number.
By their numbers in this assay, from the lowest: compound 3; then compounds 2 and 4 (each within the scatter of the next); then compound 1.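

Holding the rest of compound 1 fixed, this is the first direct reading of the group on the double-bonded chain carbon, and in this assay the exchange of naphthalen-1-yl for 4-methoxyphenyl gives a number 11 percentage points lower from compound 1 to compound 4 (beyond the scatter), so the result at this position depends on the group placed there. The exchange removes one six-membered aromatic ring and adds one hydrogen-bond acceptor, and this single step cannot separate those two changes. No measured evidence accounts for the fall in growth inhibition.

The compounds shown leave open how a plain phenyl or a 3,4-dimethoxyphenyl would compare on the chain of compound 1. They also leave open whether naphthalen-2-yl or a 4-(dimethylamino)phenyl group would keep or lose the inhibition seen with naphthalen-1-yl.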